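This account rests on a few compounds, and the source may have more. Where it says the series, first, only, none or still open, it means among the compounds named here.

The measured compounds are:

compound 1 `Nc1sc(-c2ccc(Cl)cc2)c(-c2ccc(Cl)cc2)c1C(=O)N1CCCCC1`: 14300 nM
compound 2 `Nc1sc(-c2ccc(Cl)cc2)c(-c2ccc(Cl)cc2)c1C(=O)NC1CCCCC1`: 7300 nM
compound 3 `CCCCNC(=O)c1c(N)sc(-c2ccc(Cl)cc2)c1-c1ccc(Cl)cc1`: 17800 nM

All three were tested in a functional assay on PC-3 cells (Homo sapiens) for inhibition, read by sulforhodamine B assay, with a stated time of 72 h; on this read-out higher numbers stand for weaker inhibition and lower numbers for stronger inhibition. On the bare numbers compound 1 stands between the other two, but neither neighbour is separated from it by more than the usual scatter: the step of a 2.0-fold lower number from compound 1 to compound 2 (0.29 log units; within the scatter) and the step of a 1.2-fold higher number from compound 1 to compound 3 (0.10 log units; within the scatter) both fall within it. Among the measured compounds shown here, only the step of a 2.4-fold higher number from compound 2 to compound 3 (0.39 log units; beyond the scatter) reaches just beyond the scatter, and it is modest.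

Compound 4 `CN1CCN(C(=O)c2c(N)sc(-c3ccc(Cl)cc3)c2-c2ccc(Cl)cc2)CC1` is the next compound to be measured in this assay . It differs from compound 1 in a single place: 4-methylpiperazin-1-yl in place of piperidin-1-yl on a carbonyl carbon. For the measured compounds named here, the steps that bear on this change are those that also alter the group on the carbonyl carbon of the shared core, namely a 2.0-fold lower number from compound 1 to compound 2 (0.29 log units; within the scatter) and a 1.2-fold higher number from compound 1 to compound 3 (0.10 log units; within the scatter); both are small and within the scatter. On that basis the step from compound 1 to compound 4 is expected to be small as well, with no clear direction, and is estimated at a 1.0-fold lower number from compound 1 to compound 4 (0.01 log units; within the scatter). Compound 4 is therefore expected to give about 14000 nM in this assay , with a likely range from 5000 nM to 40000 nM.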

Compound 4, half-maximal inhibitory concentration: 13100 nM
Compound 4: middle estimate off by 1.1-fold (0.03 log units), on the high side; the range from low to high includes it.
By their numbers in this assay, from the lowest: compounds 2, 4, 1 and 3 (each within the scatter of the next, the first and the last beyond it).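

In this assay the new group on the carbonyl carbon brings a second ring nitrogen, an N-methyl end and one hydrogen-bond acceptor to the ring of piperidin-1-yl, yet a 1.1-fold lower number from compound 1 to compound 4 (0.04 log units; within the scatter) shows no change that can be told from the scatter. Compound 4 also cannot be separated from either amide that keeps its hydrogen: a 1.4-fold lower number from compound 3 to compound 4 (0.13 log units; within the scatter) and a 1.8-fold higher number from compound 2 to compound 4 (0.25 log units; within the scatter) both lie within the scatter, even though compound 2 and compound 3 are themselves just beyond it, so compound 4 joins the two without adding a step of its own and the four groups now seen at this position span only a narrow band of values. No measurement shown here gives a reason for this flat picture.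

What the compounds leave open is whether this position stays as flat with a group of another kind, such as morpholin-4-yl, a benzylamino group or a carboxylic acid in place of the amide. From the compounds shown here alone, the rest of the shared core is the same in all four compounds, so it also remains open whether the change from piperidin-1-yl to 4-methylpiperazin-1-yl would read the same on a different core.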